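A few compounds are considered here, and "the series" means these few. Any claim that something is new, unique, unknown or untested is made for them only; others in the source may bear on it.

Values in a functional assay on A-375 cells (Homo sapiens) for inhibition, read by CCK-8 assay, with a stated time of 72 h; on this read-out higher numbers stand for weaker inhibition and lower numbers for stronger inhibition:

- compound 1 `Nc1ccccc1NC(=O)c1ccc(CNC(=O)c2n[nH]cc2NC(=O)c2c(F)cccc2Cl)cc1` gives 1200 nM
- compound 2 `Nc1ccccc1NC(=O)c1ccc(CNC(=O)c2n[nH]cc2NC(=O)c2ccccc2Cl)cc1` gives 2110 nM
- compound 3 `Nc1ccccc1NC(=O)c1ccc(CNC(=O)c2n[nH]cc2NC(=O)c2c(Cl)cccc2Cl)cc1` gives 1200 nM

Compound 3 reads the same as compound 1 at the digits shown, and the measured steps among these three compounds all lie within the scatter. So the three cannot be ranked. Still unmeasured is compound 4 `Nc1ccccc1NC(=O)c1ccc(CNC(=O)c2n[nH]cc2NC(=O)c2ccccc2F)cc1`. It replaces the aromatic group of compound 3, putting 2-fluorophenyl in place of 2,6-dichlorophenyl on a carbonyl carbon.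

Among the measured compounds shown here, three measured steps bear on this change, all within the same part of the molecule. They are a 1.8-fold higher number from compound 1 to compound 2 (0.25 log units; within the scatter), a 1.8-fold lower number from compound 2 to compound 3 (0.25 log units; within the scatter) and no change at the digits printed from compound 1 to compound 3 (within the scatter). Each swaps a single substituent on that aromatic ring, whereas the step to compound 4 alters the ring in more than one place. For the measured compounds named here, none of the measured compounds carries this exact group, so the forecast is an extrapolation. With no measured step beyond the scatter, no large shift is expected in this assay. Compound 2 at 2110 nM suggests a slight drift towards higher numbers at most. The expected change is a 1.4-fold higher number from compound 3 to compound 4 (0.15 log units; within the scatter), a step estimated to remain within the scatter. For compound 4 the estimated value is 1700 nM, with an expected range from 950 nM to 3200 nM.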

Compound 4, half-maximal inhibitory concentration: 2270 nM
The estimate for compound 4 lay 1.3-fold (0.13 log units) below the measured number; low and high end bracket the measured number.
By their numbers in this assay, from the lowest: compounds 1, 3, 2 and 4 (each within the scatter of the next).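

Replacing 2,6-dichlorophenyl with 2-fluorophenyl on this carbonyl carbon removes both chloro groups in one move, yet in this assay the result is a 1.9-fold higher number from compound 3 to compound 4 (0.28 log units; within the scatter), alongside a 1.1-fold higher number from compound 2 to compound 4 (0.03 log units; within the scatter) and a 1.9-fold higher number from compound 1 to compound 4 (0.28 log units; within the scatter), so all four halogen patterns on this ring remain within the scatter of one another. Compound 4 also allows each single swap to be read a second time, on a ring with a different remaining substituent, and chloro in place of fluoro gives matching results whether or not the ring carries a second chloro group: the same change on two cores in this assay, no change at the digits printed (within the scatter) from compound 1 to compound 3 and a 1.1-fold lower number (0.03 log units; within the scatter) from compound 4 to compound 2, 1.1-fold (0.03 log units) apart, within the scatter of two such steps. Chloro in place of hydrogen likewise gives matching results whether the ring already carries a chloro or a fluoro group, so within these four compounds the swaps look independent of each other, although every step is small: the same change on two cores in this assay, a 1.8-fold lower number (0.25 log units; within the scatter) from compound 2 to compound 3 and a 1.9-fold lower number (0.28 log units; within the scatter) from compound 4 to compound 1, 1.1-fold (0.03 log units) apart, within the scatter of two such steps.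

These compounds cannot be ranked, and they cannot show why the numbers stay so close, since all of them carry only chloro or fluoro on this ring. As far as these compounds go, whether a methoxy group, a nitrile or an amine on the ring would move the number beyond the scatter remains open.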